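Isopentyloxy to propoxy on compound 1

The compounds below may be only part of what the source reports. "The series", "measured", "known", "first", "only" and "open" are said of these compounds alone.

Among the compounds with values here, in a functional assay on A549 cells (Homo sapiens) for antiproliferative activity, read by sulforhodamine B assay, with a stated time of 3 days (on this read-out higher numbers stand for an effect only at larger amounts of compound and lower numbers for an effect already at smaller amounts), compound 1 (`CCCC1=C(OCCC(C)C)C(CCC)(CCC)C(=O)/C(=C(O)\C=C\c2ccccc2)C1=O`) gives 11.3 uM and compound 2 (`CCCCC1=C(OC)C(CCCC)(CCCC)C(=O)/C(=C(O)\C=C\c2ccccc2)C1=O`) gives 6.4 uM with the two values within the scatter of each other, so compound 1 cannot be separated from compound 2 on the only two numbers available. Compound 3 (`CCCOC1=C(CCC)C(=O)/C(=C(O)/C=C/c2ccccc2)C(=O)C1(CCC)CCC`) carries methyl in place of isopropyl on a saturated chain carbon, two bonds along the chain from an oxygen on an unsaturated carbon, which also reads isopentyloxy to propoxy. Within the data shown here, no measured step isolates this change, so no shift beyond the scatter is expected in this assay in either direction. The estimated step (a 1.3-fold lower number from compound 1 to compound 3 (0.10 log units; within the scatter)) stays small. For compound 3 the estimated value is 9 uM with an expected range from 4 uM to 20 uM on this read-out.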

Compound 3, concentration for half-maximal effect: 1.9 uM
The estimate for compound 3 lay 4.7-fold (0.68 log units) above the measured number; measured number outside the range, below it.
By their numbers in this assay, from the lowest: compound 3; then compounds 2 and 1 (each within the scatter of the next).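

In this assay, within the data shown here, the change from isopentyloxy to propoxy gives a 5.9-fold lower number from compound 1 to compound 3 (0.77 log units; beyond the scatter) and is the first single-place change that can be read. The position is therefore not silent: methyl in place of isopropyl on a saturated chain carbon, two bonds along the chain from an oxygen on an unsaturated carbon, moves the number beyond the scatter. No measured evidence accounts for this shift.

As far as these compounds go, whether a shorter chain such as ethoxy would lower the number further remains open. So does the outcome with an amine or a carboxylic acid in place of the isopentyloxy group.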